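Demethylation of the dimethylcatechol indole core

The source may hold more compounds than are shown below. What is called first, only, known or untested is meant among the compounds shown, and "the series" means these compounds.

Among the measured compounds shown here, compound 1 `Cc1c(O)c(O)c(C)c2[nH]ccc12` gives 7260000 nM in an assay on isolated protein with Catechol O-methyltransferase (Rattus norvegicus) as the target (on this read-out higher numbers stand for weaker inhibition and lower numbers for stronger inhibition), the lowest of the two numbers so far. Compound 2 `Cc1c(O)c(O)cc2[nH]ccc12`, which carries a hydrogen in place of a methyl on an aromatic carbon, gives 15200000 nM in this assay, so the step of a 2.1-fold higher number from compound 1 to compound 2 (0.32 log units; beyond the scatter) went toward weaker inhibition by a modest margin.

Compound 3 `Cc1c(O)c(O)cc2cc[nH]c12` is not yet measured. It differs from compound 1 by hydrogen in place of methyl on an aromatic carbon. For the measured compounds named here, the change resembles the one from compound 1 to compound 2: again a methyl is lost from an aromatic carbon that sits ortho to a hydroxy group and ortho to a fused ring, only on the other side of the shared core. Going by the values given here, that step is therefore the one measured step that bears on the expectation, and it was a 2.1-fold higher number from compound 1 to compound 2 (0.32 log units; beyond the scatter).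

On that basis a step of similar size and direction, toward a higher number, is expected for compound 3 in this assay, namely a 1.8-fold higher number from compound 1 to compound 3 (0.25 log units; within the scatter). Among the compounds with values here, the estimate for compound 3 is 13000000 nM, with a range from 6000000 nM to 30000000 nM; since only one comparable step exists, the range is kept wide.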

Compound 3, inhibition constant: 1140000 nM
Compound 3: the middle estimate sits 11-fold (1.06 log units) above what was measured; measured number below the stated range.
By their numbers in this assay, from the lowest: compound 3; then compound 1; then compound 2.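

Exchanging methyl for hydrogen does not have one direction across the shared core: in this assay the change at this position gives a 6.4-fold lower number from compound 1 to compound 3 (0.80 log units; beyond the scatter) and goes toward stronger inhibition, whereas the same exchange at the other methyl of compound 1 gave a 2.1-fold higher number from compound 1 to compound 2 (0.32 log units; beyond the scatter) and went toward weaker inhibition. Both steps lie beyond the scatter, so the two methyl groups of compound 1 cannot be treated as interchangeable, and the methyl on the aromatic carbon ortho to a fused ring, ortho to a hydroxy group and para to a methyl group is the one whose loss favours inhibition on this read-out. Nothing at hand accounts for the opposite directions of the two steps.

The compounds shown carry only methyl or hydrogen at this position, so it remains open how an ethyl group, a chlorine atom, an amine or a carboxylic acid would read there. Also open, from the compounds shown here alone, is how the two single steps combine in a compound with hydrogen on both of these aromatic carbons.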